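A few compounds are considered here, and "the series" means these few. Any claim that something is new, unique, unknown or untested is made for them only; others in the source may bear on it.

For the measured compounds named here, compound 1 `CS(=O)(=O)c1cc(F)ccc1NCC1=NCCN1` gives the weakest binding of the three measured members: in an assay for binding affinity to Alpha-1D adrenergic receptor (Homo sapiens), read by radioligand binding (a higher number here means a weaker inhibitor, a lower number a stronger inhibitor), compound 1 gives 1620 nM. Compound 2 `CSc1ccc(F)cc1NCC1=NCCN1` is far stronger, as in this assay compound 2 gives 6.17 nM; the difference between the two cores is not broken down here. Compound 3 `CSc1ccc(Cl)cc1NCC1=NCCN1` differs from compound 2 by chloro in place of fluoro on an aromatic carbon and in this assay compound 3 gives 4.68 nM, a step of a 1.3-fold lower number from compound 2 to compound 3 (0.12 log units; within the scatter). Compound 4 `CS(=O)(=O)c1cc(Cl)ccc1NCC1=NCCN1` carries the same kind of change relative to compound 1, (chloro in place of fluoro on an aromatic carbon), though not the same one: here the site is meta to a methylsulfonyl group (4 heavy atoms) and para to a group of 7 heavy atoms, whereas in compound 2 it is meta to a group of 7 heavy atoms and para to a methylsulfanyl group (2 heavy atoms). In this assay the expected step is a 1.2-fold lower number from compound 1 to compound 4 (0.10 log units; within the scatter), resting on a 1.3-fold lower number from compound 2 to compound 3 (0.12 log units; within the scatter). Compound 4 is estimated at 1300 nM, with a range from 500 nM to 3500 nM.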

Compound 4, inhibition constant: 871 nM
Beside the measured number, compound 4's estimate is 1.5-fold (0.17 log units) above it; low and high end bracket the measured number.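

Chloro in place of fluoro on an aromatic carbon gives, in this assay, a 1.9-fold lower number from compound 1 to compound 4 (0.27 log units; within the scatter). Set beside the same change on the core of compound 2, this step shows no difference that stands out: the same change on two cores in this assay, a 1.3-fold lower number (0.12 log units; within the scatter) from compound 2 to compound 3 and a 1.9-fold lower number (0.27 log units; within the scatter) from compound 1 to compound 4, 1.4-fold (0.15 log units) apart, within the scatter of two such steps. So the change carries across these two cores without a detectable shift, but both steps lie within the scatter, and two pairs neither separate chloro from fluoro nor give a rule for other cores.

As far as these compounds go, it remains open whether a larger group at this carbon, such as methoxy or trifluoromethyl, would also agree between the two cores. The same question applies to an amine or a carboxylic acid there.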